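Pyridyl Gives Way to Fluoromethoxyphenyl in a Cytotoxicity Series

The compounds below may be only part of what the source reports. "The series", "measured", "known", "first", "only" and "open" are said of these compounds alone.

Compound 3 `CCOC(=O)CCCCCOc1cccc(CN(C(=O)c2ccc(-c3ccncc3)cc2)C(C)C)c1` gives in an ADME assay on HEK293 cells (Homo sapiens) for cytotoxicity, read by CellTiter-Glo and resazurin assay, with a stated time of 72 h (a lower number here means that less compound is needed, a higher number that more compound is needed for the effect), only a limit, > 26000 nM. Its neighbours are equally silent. Compound 1 `CC(C)N(Cc1cccc(OCCCCCC(=O)O)c1)C(=O)c1ccc(-c2ccncc2)cc1` gives in this assay a limit, > 26000 nM. Compound 2 `CC(C)N(Cc1cccc(OCCCCCC(=O)O)c1)C(=O)c1ccc(-c2cccc([N+](=O)[O-])c2)cc1` gives in this assay a limit, > 26000 nM. Consequently the step that the two limits leave unreadable from compound 1 to compound 2 and the step that the two limits leave unreadable from compound 1 to compound 3 are both unreadable, and every measured value sits at the limit of > 26000 nM in this assay, at which 3 of the 3 values shown sit. Compound 3 thus stands exactly where its companions stand, at the limit, with no number of its own.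

Compound 4 `CCOC(=O)CCCCCOc1cccc(CN(C(=O)c2ccc(-c3cc(F)cc(OC)c3)cc2)C(C)C)c1` differs from compound 3 in one place: 3-fluoro-5-methoxyphenyl in place of pyridin-4-yl on an aromatic carbon. Within the data shown here, no measured step involves an aryl group of this kind, and the one aryl exchange that was measured, from pyridin-4-yl to 3-nitrophenyl, is hidden between two limits. Nothing in the series points toward a measurable effect appearing once the pyridin-4-yl is exchanged. The expected step is therefore a step that the limit leaves unreadable from compound 3 to compound 4, none beyond the scatter, with the reservation that a limit cannot carry a size. For compound 4 the expected value in this assay is 30000 nM, ranging from 15000 nM to 90000 nM, most probably reported again as a limit.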

Compound 4, half-maximal effective concentration: > 26000 nM
Compound 4: no number, only a limit; the forecaster's own chance of this, stated with the estimate: 85%; the middle value is on the limit's open side.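

In this assay compound 4 gives > 26000 nM, a limit and not a number. Among these compounds, compound 3 also stands at a limit, so no step between compound 3 and compound 4 can be read. The compounds shown leave open what size, if any, the aryl exchanges or the ethyl ester have in this series, as all of them remain at one limit: the limit of > 26000 nM in this assay, at which 4 of the 4 values shown sit.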